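This account rests on a few compounds, and the source may have more. Where it says the series, first, only, none or still open, it means among the compounds named here.

Compound 3 `COc1ccc(-n2ccc(=O)c(C(=O)Nc3ccc(Oc4ccnc5[nH]ccc45)c(F)c3)n2)cc1` gives the highest number of the three compounds measured in a functional assay on MCF7 cells (Homo sapiens) for cytotoxicity, read by MTT assay, with a stated time of 72 h (a higher number here means a weaker inhibitor, a lower number a stronger inhibitor), namely 55400 nM. Its nearest neighbour is compound 1 `COc1ccc(-n2ccc(=O)c(C(=O)Nc3ccc(Oc4ccnc5[nH]ccc45)cc3)n2)cc1`, which in this assay gives 21600 nM; the step of a 2.6-fold higher number from compound 1 to compound 3 (0.41 log units; beyond the scatter) is modest but beyond the scatter. Furthest away lies compound 2 `O=C(Nc1ccc(Oc2ccnc3[nH]ccc23)cc1)c1nn(-c2ccccc2)ccc1=O`, which gives 15600 nM in this assay; the step of a 1.4-fold lower number from compound 1 to compound 2 (0.14 log units; within the scatter) stays within the scatter. Compound 4 `O=C(Nc1ccc(Oc2ccnc3[nH]ccc23)c(F)c1)c1nn(-c2ccc(Cl)c(F)c2)ccc1=O` has not yet been measured. It differs from compound 3 in one place: 4-chloro-3-fluorophenyl in place of 4-methoxyphenyl on an aromatic nitrogen. The group that leaves is 4-methoxyphenyl and the group that enters is 4-chloro-3-fluorophenyl, on an aromatic nitrogen. Going by the values given here, the only measured step that touches this part of the molecule is a 1.4-fold lower number from compound 1 to compound 2 (0.14 log units; within the scatter), where taking away the methoxy left the number within the scatter, so the substituent on this phenyl has so far mattered little. Among the compounds with values here, no measured step covers the chloro and fluoro substitution itself, and the two halogens remain untested. The expected step in this assay is therefore small, a 1.6-fold lower number from compound 3 to compound 4 (0.20 log units; within the scatter), with a lean toward a somewhat lower number. Compound 4 is estimated to give 35000 nM in this assay, within a range from 12000 nM to 100000 nM.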

Compound 4, half-maximal inhibitory concentration: 11600 nM
Beside the measured number, compound 4's estimate is 3.0-fold (0.48 log units) above it, outside the stated range (below it).
By their numbers in this assay, from the lowest: compounds 4, 2 and 1 (each within the scatter of the next); then compound 3.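

Going by these compounds alone, the phenyl group on the aromatic nitrogen proves to be a position that can move the number: the only earlier step here, a 1.4-fold lower number from compound 1 to compound 2 (0.14 log units; within the scatter), stayed within the scatter, whereas in this assay the change to 4-chloro-3-fluorophenyl gives a 4.8-fold lower number from compound 3 to compound 4 (0.68 log units; beyond the scatter), which is modest but beyond it. The exchange keeps the single six-membered aromatic ring and the count of 8 heavy atoms, so the step arises without any change in the size of the group by that count, although the entering group has 0 hydrogen-bond acceptors against 1 in the group that leaves. Nothing in the data shown accounts for this step.

The compounds shown leave open whether the chloro or the fluoro carries the step, since a 4-chlorophenyl or a 3-fluorophenyl group on this nitrogen does not appear among them. They also leave open whether the same change would hold on the core of compound 1, which lacks the fluoro of compound 3, and how a phenyl bearing an amine or a carboxylic acid would behave at this position.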